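From Acetyl to 1-Hydroxyethyl on a Shared Core

The source may hold more compounds than are shown below. What is called first, only, known or untested is meant among the compounds shown, and "the series" means these compounds.

Compound 1 `CC(=O)c1ccc2[nH]c(-c3ccccc3)nc2c1` shows the shared core with an acetyl group, and in an ADME assay on MT4 cells (Homo sapiens) for cytotoxicity, read by MTT assay, with a stated time of 96 h (on this read-out lower numbers stand for higher toxicity in this test and higher numbers for lower toxicity in this test), compound 1 gives "not determined" (no result reported). Compound 2 `COc1ccc(-c2nc3cc(C(C)=O)ccc3[nH]2)c(OC)c1OC` also carries an acetyl group. In this assay compound 2 gives > 100000 nM, which is a limit of the assay and not a number. Compound 4 `COc1ccc(-c2nc3cc(C(C)O)ccc3[nH]2)c(OC)c1OC` differs from compound 2 by having 1-hydroxyethyl in place of acetyl on an aromatic carbon. Compound 3 `COc1ccc(-c2nc3cc(C(C)O)ccc3[nH]2)cc1` also bears a 1-hydroxyethyl group, and its result of >= 100000 nM is likewise a limit. On that basis, the expected step of a number no higher from compound 2 to compound 4 (the limit leaves the size open) is none beyond the usual scatter, in either direction. Compound 4 is estimated at 100000 nM, with an expected range from 50000 nM to 200000 nM.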

Compound 4, half-maximal cytotoxic concentration: 79000 nM
Estimate against measurement, compound 4: 1.3-fold (0.10 log units) above; the range from low to high includes it.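

In this assay, within the data shown here, putting 1-hydroxyethyl in place of acetyl on this aromatic carbon gives an at least 1.2-fold lower number from compound 2 to compound 4 (0.10 log units; that floor lies within the scatter), the first step that can be read on the shared core. The data therefore require no real change in toxicity in this test from this swap. As far as these compounds go, the true size of the step stays open, since compound 2 has only a limit and not a number: the limit of > 100000 nM in this assay, at which 1 of the 4 values shown sits.

From the compounds shown here alone, how an amine or a carboxylic acid at this position would read remains open.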